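Cytotoxicity of methylenecyclopropane purine analogues

This account rests on a few compounds, and the source may have more. Where it says the series, first, only, none or still open, it means among the compounds named here.

Compound 1 `CCCCSc1nc(N)nc2c1ncn2/C=C1/CC1(CO)CO`: in an ADME assay on BCBL1 cells (Homo sapiens) for cytotoxicity, with a stated time of 7 days (on this read-out lower numbers stand for higher toxicity in this test and higher numbers for lower toxicity in this test), compound 1 gives > 20000 nM, a limit of the test rather than a number.
Compound 2 `Nc1nc(NCc2ccccc2)c2ncn(/C=C3/CC3(CO)CO)c2n1`: in this assay compound 2 gives 19900 nM.
Compound 3 `CCCCNc1nc(N)nc2c1ncn2/C=C1/CC1(CO)CO`: in this assay compound 3 gives > 20000 nM, again a limit rather than a number.

Compound 3 therefore stands at the limit at which two of the three measured values sit (the limit of > 20000 nM in this assay, at which 2 of the 3 values shown sit). The next compound, compound 4 `Nc1nc(NC2CCCC2)c2ncn(/C=C3/CC3(CO)CO)c2n1`, differs from compound 3 in one place (cyclopentyl in place of butyl on a nitrogen on an aromatic ring). For the measured compounds named here, none of the measured steps touches this kind of change. The step of a number no lower from compound 2 to compound 3 (the limit leaves the size open) and the step that the two limits leave unreadable from compound 1 to compound 3 lead into compound 3, and both leave their size open, so nothing can be read from them about the size of a step leaving compound 3. With no readable step to lean on, the expectation is that compound 4 stays about where compound 3 stands, a step of a number no higher from compound 3 to compound 4 (the limit leaves the size open). Compound 4 is therefore expected to give 20000 nM in this assay, estimated between 10000 nM and 40000 nM, most likely reported again as a limit.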

Compound 4, half-maximal cytotoxic concentration: 71700 nM
Compound 4: middle estimate off by 3.6-fold (0.55 log units), on the low side, and the stated range ends below it.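

For the compounds shown here, changing the group on a nitrogen on an aromatic ring from benzyl to cyclopentyl gives the first step of readable size in this set. In this assay, that step is a 3.6-fold higher number from compound 2 to compound 4 (0.56 log units; beyond the scatter), and a higher number on this read-out stands for lower toxicity in this test. So the group on this nitrogen can shift the read-out by more than the usual scatter, at least for this pair. The steps to compound 4 from compound 1 and from compound 3 cannot be read, since each of those two compounds carries a limit and not a number: the limit of > 20000 nM in this assay, at which 2 of the 4 values shown sit.

As far as these compounds go, it stays open how butyl and cyclopentyl truly compare on this nitrogen, since only one of the two has a number. From the compounds shown here alone, it is also open where a smaller ring such as cyclopropyl or a larger one such as cyclohexyl would fall relative to compound 4.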